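The source may hold more compounds than are shown below. What is called first, only, known or untested is meant among the compounds shown, and "the series" means these compounds.

Of the compounds shown here, three have so far been tested in an assay on isolated protein for inhibition of Indoleamine 2,3-dioxygenase 1 (Homo sapiens), with a stated time of 60 min, tested at 10 uM; on this read-out higher numbers stand for more inhibition at the one concentration tested (going by the name of the read-out) and lower numbers for less inhibition. Compound 1 `c1ccc(CCc2ccccc2CSC2=NCCS2)cc1` gives 0% and stands lowest of the three. Compound 2 `O=S(=O)(Cc1ccccc1)c1ccccc1CSc1nc2cc(Cl)ccc2[nH]1` gives 24% in this assay, and compound 3 `[O-][S+](Cc1ccccc1)c1ccccc1CSc1nc2cc(Cl)ccc2[nH]1` gives 11%; both of these numbers lie beyond the usual scatter above the number for compound 1, with compound 2 the further from it. Compound 4 `c1ccc(CCc2ccccc2CSC2=NCCN2)cc1` has not yet been measured in this assay. It differs from compound 1 in one place: a group of 5 heavy atoms (3 carbon, 2 nitrogen; one five-membered non-aromatic ring with 2 hetero atoms) in place of a group of 5 heavy atoms (3 carbon, 1 nitrogen, 1 sulfur; one five-membered non-aromatic ring with 2 hetero atoms), on a sulfur. Within the data shown here, no measured pair shows this change, so nothing is known of its effect. The expected step is a number 5 percentage points higher from compound 1 to compound 4 (within the scatter), that is, no change beyond the scatter in either direction. Compound 4 is therefore estimated at 5% in this assay, with a range from -8% to 20%.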

Compound 4, a percentage reported as inhibition, at one concentration (the size of the read-out at that concentration, not a potency): 17%
The estimate for compound 4 lay 12 percentage points below the measured number; low and high end bracket the measured number.
By their numbers in this assay, from the lowest: compound 1; then compounds 3, 4 and 2 (each within the scatter of the next, the first and the last beyond it).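

Among these compounds, this is the first step read at this place, on a sulfur whose other neighbours are a saturated chain carbon: in this assay, the ring with 2 nitrogen in place of the ring with 1 nitrogen and 1 sulfur gives a number 17 percentage points higher from compound 1 to compound 4 (beyond the scatter). The exchange also brings in 1 hydrogen-bond donor, but the data do not tie the step to it. Nothing on hand accounts for the step. Going by these compounds, whether a ring holding oxygen, or an open-chain amine on that sulfur, would give a similar step remains open, as does the same exchange on the core of compound 2.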